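Ester side chain exchange on compound 2

This account rests on a few compounds, and the source may have more. Where it says the series, first, only, none or still open, it means among the compounds named here.

Three compounds have numbers in a functional assay on T-24 cells (Homo sapiens) for antiproliferative activity, read by sulforhodamine B assay, with a stated time of 72 h; a higher number here means a weaker inhibitor, a lower number a stronger inhibitor. Compound 1 `CCCSC(=O)COC(=O)C1=C2C(=NC1=O)c1cccc3cccc2c13` gives 10500 nM. Compound 2 `CCCSc1ccc2c3c(cccc13)C1=NC(=O)C(C(=O)OCC)=C12` gives 1700 nM, and compound 3 `C=CCSc1ccc2c3c(cccc13)C1=NC(=O)C(C(=O)OCC)=C12` gives 700 nM. Compound 2 therefore holds the second highest of the three numbers; its nearest neighbour is compound 3, reached by a 2.4-fold lower number from compound 2 to compound 3 (0.39 log units; beyond the scatter), while compound 1 sits furthest away with the highest number of the set.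

Compound 4 `CCCSC(=O)COC(=O)C1=C2C(=NC1=O)c1cccc3c(SCCC)ccc2c13` has not yet been measured. It differs from compound 2 by (propylsulfanyl)carbonyl in place of methyl on a saturated chain carbon bound to an oxygen next to a carbonyl group. Among the compounds with values here, the one measured step, a 2.4-fold lower number from compound 2 to compound 3 (0.39 log units; beyond the scatter), concerns the group on a saturated chain carbon bound to a sulfur and leaves this side chain untouched, so it gives no direct guide. Compound 1 carries the same (((propylsulfanyl)carbonyl)methoxy)carbonyl side chain as compound 4 but differs from compound 2 in two places, so only the two values can be set side by side: compound 1 at 10500 nM against compound 2 at 1700 nM. On that reading a step toward a higher number is expected, a 2.9-fold higher number from compound 2 to compound 4 (0.47 log units; beyond the scatter). Compound 4 is thus estimated at 5000 nM, within 1500 nM to 15000 nM.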

Compound 4, half-maximal inhibitory concentration: 79100 nM
Compound 4: middle estimate off by 16-fold (1.20 log units), on the low side; the whole stated range lies below it.
By their numbers in this assay, from the lowest: compound 3; then compound 2; then compound 1; then compound 4.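

In this assay, within the data shown here, the first measured change at this side chain brings a large loss: placing (propylsulfanyl)carbonyl instead of methyl on the saturated chain carbon bound to an oxygen next to a carbonyl group gives a 47-fold higher number from compound 2 to compound 4 (1.67 log units; beyond the scatter). The aromatic propylsulfanyl group does not offset this loss, since with the side chain held constant, propylsulfanyl in place of hydrogen on an aromatic carbon gives a 7.5-fold higher number from compound 1 to compound 4 (0.88 log units; beyond the scatter). The ethoxycarbonyl side chain of compound 2 therefore outperforms the (((propylsulfanyl)carbonyl)methoxy)carbonyl side chain on the propylsulfanyl-bearing core.

The compounds shown leave open whether the loss follows the whole (propylsulfanyl)carbonyl group or only the longer side chain, a question that a plain longer alkyl ester or a carboxylic acid at this position would address. No supporting evidence bears on why this side chain change costs so much activity.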